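Swapping One Aryl Group on a Flat Core

This account rests on a few compounds, and the source may have more. Where it says the series, first, only, none or still open, it means among the compounds named here.

Measured in a functional assay on B16-F10 cells (Mus musculus) for cytotoxicity; a lower number here means a stronger inhibitor, a higher number a weaker inhibitor:
- compound 1 `O=c1oc2ccccc2c2nc3c(ccc4cc[nH]c43)c(-c3c(Cl)cccc3Cl)c12`: 70700 nM
- compound 2 `O=c1oc2ccccc2c2nc3c(ccc4cc[nH]c43)c(-c3ccc(O)cc3)c12`: 70700 nM
- compound 3 `O=c1oc2ccccc2c2nc3c(ccc4cc[nH]c43)c(-c3ccccc3Br)c12`: 70700 nM

Compound 3, at 70700 nM, stands level with compound 1 and compound 2, so none of the three leads the set. Among the measured compounds shown here, the next compound keeps the shared core and changes only one group. Compound 4 `O=c1oc2ccccc2c2nc3c(ccc4cc[nH]c43)c(-c3ccc(F)cc3)c12` has 4-fluorophenyl in place of 2-bromophenyl on an aromatic carbon.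

All three measured steps changed the group at this same carbon, which makes them the best available guide. For the measured compounds named here, the first is no change at the digits printed from compound 1 to compound 2 (within the scatter). The second is no change at the digits printed from compound 1 to compound 3 (within the scatter), and the third is no change at the digits printed from compound 2 to compound 3 (within the scatter). Three different groups therefore gave the same reading here. Compound 2 also carries its group at the 4-position of the phenyl ring, and its step to compound 3, no change at the digits printed from compound 2 to compound 3 (within the scatter), shows no effect from moving away from that pattern. Going by the values given here, no measured compound contains fluorine, so this prediction reaches slightly beyond the data.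

The expected result is no change at the digits printed from compound 3 to compound 4 (within the scatter), with no shift in either direction beyond the scatter. Compound 4 is estimated at 70700 nM, with an expected range from 35000 nM to 100000 nM.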

Compound 4, half-maximal inhibitory concentration: 70700 nM
Beside the measured number, compound 4's estimate shows no gap at the digits printed; the measured number falls inside the stated range.
By their numbers in this assay, from the lowest: compounds 1, 2, 3 and 4 (each within the scatter of the next).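

The newest comparison is the tightest so far, since only one substituent on the aryl group differs: with fluoro in place of hydroxy on an aromatic carbon, this assay shows no change at the digits printed from compound 2 to compound 4 (within the scatter). Fluorine, the one element new to this set, also leaves the reading in place against the two other groups, with no change at the digits printed from compound 3 to compound 4 (within the scatter) for 4-fluorophenyl in place of 2-bromophenyl and no change at the digits printed from compound 1 to compound 4 (within the scatter) for 4-fluorophenyl in place of 2,6-dichlorophenyl, so four differently substituted phenyl groups at this carbon now give the same printed value, and none of the four goes against that pattern. Nothing available here accounts for why these readings coincide.

As far as these compounds go, all four compounds carry a substituted phenyl ring at this carbon, so it remains open whether an amine, a carboxylic acid or a longer alkyl chain in that place would give a different reading. All four also share the same core, which leaves open how a change anywhere else on it, such as replacing the ring nitrogen's hydrogen with a methyl group, would read in this assay.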